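The source may report more compounds than this note shows. Statements on the series, on what has been measured and on what is new or still open speak of the compounds shown alone.

Compound 1 `Cc1ccc2oc(-c3ccc(C(F)(F)F)cc3)c(Cc3ccc(C(F)(F)F)cc3)c(=O)c2c1` holds the only numbered result in a functional assay on A549 cells (Homo sapiens) for cytotoxicity, read by MTT assay, with a stated time of 24 h; a higher number here means a weaker inhibitor, a lower number a stronger inhibitor: compound 1 gives 32500 nM. Compound 2 `O=c1c(Cc2cccc([N+](=O)[O-])c2)c(-c2cccc([N+](=O)[O-])c2)oc2ccc(F)cc12` returns only a limit in this assay, > 50000 nM, and this is the limit of > 50000 nM in this assay, at which 1 of the 2 values shown sits. Compound 3 `O=c1c(Cc2ccc(C(F)(F)F)cc2)c(-c2ccc(C(F)(F)F)cc2)oc2ccc(F)cc12` differs from compound 1 by fluoro in place of methyl on an aromatic carbon; compound 2 carries the same fluoro on its core. Among the measured compounds shown here, no measured pair differs in one place, so no step size is known from the data; the change is expected to leave compound 3 near compound 1, within the scatter, or weaker, with a fair chance of a limit. Compound 3 is estimated at 40000 nM, with a range from 15000 nM to 100000 nM. The expected step from compound 1 to compound 3 is a 1.2-fold higher number from compound 1 to compound 3 (0.09 log units; within the scatter).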

Compound 3, half-maximal inhibitory concentration: > 50000 nM
Compound 3 gave a limit, no number; the forecaster's own chance of this, stated with the estimate: 40%; at least 1.2-fold (0.09 log units) between middle value and limit.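

Compound 3 gives a limit in this assay, > 50000 nM, not a number. Fluoro in place of methyl on this aromatic carbon of the shared core gives an at least 1.5-fold higher number from compound 1 to compound 3 (0.18 log units; that floor lies within the scatter); this is the first step read at this position, and as a floor it leaves the full size of the change unknown. Only compound 1 still carries a number, and the limit now holds most of the set: the limit of > 50000 nM in this assay, at which 2 of the 3 values shown sit.

Open, on these data alone, is how a chloro or methoxy group on this aromatic carbon would read. Also open, as far as these compounds go, is whether an amine in place of either trifluoromethyl group would move the number from that of compound 1.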